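Notes on compound 4: fluoro in place of hydrogen

The compounds below may be only part of what the source reports. "The series", "measured", "known", "first", "only" and "open" are said of these compounds alone.

Measured compounds:
compound 1 `N/C(=N\NC(=S)N1CCCC1)c1ccc(F)cn1`: 77.7%
compound 2 `Cc1ccnc(/C(N)=N/NC(=S)N2CCSCC2)c1`: 40.4%
compound 3 `N/C(=N\NC(=S)N1CCSCC1)c1ccccn1`: 39.7%

In a functional assay on HeLa cells (Homo sapiens) for cytotoxicity, read by MTT assay, with a stated time of 72 h, tested at 3 uM (on this read-out higher numbers stand for more inhibition of growth at the one concentration tested and lower numbers for less inhibition of growth), compound 3 gives 39.7%, the lowest of the three numbers. Compound 2 gives 40.4%, and the step of a number 0.7 percentage points lower from compound 2 to compound 3 (within the scatter) is within the scatter, so these two are not separated. Within the data shown here, compound 1 gives 77.7%, a higher number, and this gap lies beyond the scatter; compound 1 differs from compound 3 in two places, however, so no single step is defined between them.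

Compound 4 `N/C(=N\NC(=S)N1CCSCC1)c1ccc(F)cn1` differs from compound 3 by fluoro in place of hydrogen on an aromatic carbon. Among the measured compounds shown here, no measured step covers this change on its own. For the measured compounds named here, the only measured step, a number 0.7 percentage points lower from compound 2 to compound 3 (within the scatter), concerns a different change and is within the scatter. Compound 1 carries the same fluoro but also another ring elsewhere in the structure, so its higher number cannot be assigned to the fluoro alone. The direction is therefore open; an increase is possible but not established, and the range is set wide. Compound 4 is expected at 52%, with a range from 32% to 75%. The expected step is a number 12.3 percentage points higher from compound 3 to compound 4 (beyond the scatter).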

Compound 4, percent growth inhibition at one concentration: 62.9%
The estimate for compound 4 lay 10.9 percentage points below the measured number; the measured number falls inside the stated range.
By their numbers in this assay, from the lowest: compounds 3 and 2 (each within the scatter of the next); then compound 4; then compound 1.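

In this assay, among these compounds, fluoro in place of hydrogen on the aromatic carbon two atoms from the ring nitrogen and para to a large group gives a number 23.2 percentage points higher from compound 3 to compound 4 (beyond the scatter); with thiomorpholin-4-yl held fixed, this position therefore responds to the change, which the earlier compounds could not show. With the fluoro held fixed, thiomorpholin-4-yl in place of pyrrolidin-1-yl on the thiocarbonyl carbon gives a number 14.8 percentage points lower from compound 1 to compound 4 (beyond the scatter), so the number of compound 1 cannot be assigned to the fluoro alone. Nothing available explains either step.

Open, as far as these compounds go, is whether chloro or methoxy at this position would move the number as fluoro does. Also open, from the compounds shown here alone, is whether the fluoro step keeps its size with pyrrolidin-1-yl on the thiocarbonyl carbon.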